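Swapping pyridin-3-yl for phenyl: notes on compound 4

This account rests on a few compounds, and the source may have more. Where it says the series, first, only, none or still open, it means among the compounds named here.

Measured in a functional assay on NCI-H460 cells (Homo sapiens) for cytotoxicity, read by MTT assay, with a stated time of 72 h; on this read-out higher numbers stand for weaker inhibition and lower numbers for stronger inhibition:
- compound 1 `Cc1[nH]cnc1/C=c1\[nH]c(=O)/c(=C/c2cccc(Oc3ccc(F)cc3)c2)[nH]c1=O`: 47.6 nM
- compound 2 `O=c1[nH]/c(=C\c2ccccn2)c(=O)[nH]/c1=C\c1cccc(Oc2ccc(F)cc2)c1`: 49.1 nM
- compound 3 `O=c1[nH]/c(=C\c2cccc(Oc3ccc(F)cc3)c2)c(=O)[nH]/c1=C\c1cccnc1`: > 1000 nM (a limit)

Compound 3 reads > 1000 nM in this assay, and this is a limit of the assay and not a number. Among the compounds with values here, the series so far shows (the limit of > 1000 nM in this assay, at which 1 of the 3 values shown sits).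

Compound 4 `O=c1[nH]/c(=C\c2cccc(Oc3ccc(F)cc3)c2)c(=O)[nH]/c1=C\c1ccccc1` is not yet measured. Its difference from compound 3 is phenyl in place of pyridin-3-yl on a double-bonded chain carbon bound to an aromatic carbon; the swap is phenyl in place of pyridin-3-yl on a double-bonded chain carbon bound to an aromatic carbon.

Within the data shown here, no measured compound carries phenyl at this place, so the evidence is indirect. Two measured steps at the same carbon are large and beyond the scatter: an at least 21-fold higher number from compound 1 to compound 3 (1.32 log units; beyond the scatter) and an at least 20-fold higher number from compound 2 to compound 3 (1.30 log units; beyond the scatter). A third, a 1.0-fold higher number from compound 1 to compound 2 (0.01 log units; within the scatter), lies within the scatter. Exchanging the ring here has therefore sometimes mattered greatly and sometimes not at all.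

Two of the three rings give numbers, with compound 1 at 47.6 nM and compound 2 at 49.1 nM. A large move towards stronger inhibition is thus expected, though its size is poorly fixed. The estimated change is an at least 6.6-fold lower number from compound 3 to compound 4 (0.82 log units; beyond the scatter). In this assay compound 4 is estimated at 150 nM, with an expected range of 40 nM to 600 nM.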

Compound 4, half-maximal inhibitory concentration: 389 nM
Beside the measured number, compound 4's estimate is 2.6-fold (0.41 log units) below it, and the stated range covers the measured number.
By their numbers in this assay, from the lowest: compounds 1 and 2 (each within the scatter of the next); then compound 4. At a limit, above all of these: compound 3.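

Compound 3 remains a limit and not a number in this assay: the limit of > 1000 nM in this assay, at which 1 of the 4 values shown sits.

Phenyl, a six-membered aromatic ring of carbon only, gives a measured number at this carbon, and the swap from pyridin-3-yl produces an at least 2.5-fold lower number from compound 3 to compound 4 (0.41 log units; beyond the scatter); a ring without nitrogen is therefore not the poorest of the rings shown here. Phenyl still falls short of the two best rings, with a 7.9-fold higher number from compound 2 to compound 4 (0.90 log units; beyond the scatter) and an 8.2-fold higher number from compound 1 to compound 4 (0.91 log units; beyond the scatter), so this position now has three levels in place of two: pyridin-2-yl and 5-methyl-1H-imidazol-4-yl together, then phenyl, then pyridin-3-yl. A ring nitrogen thus does not push in one direction, since pyridin-2-yl lies on the stronger side of phenyl and pyridin-3-yl on the weaker side.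

As far as these compounds go, the full size of the step from pyridin-3-yl to phenyl stays open, as only one end of it is a number. Also open is whether this carbon tolerates anything other than the plain aromatic rings shown, for example phenyl bearing a dimethylamino group or a carboxylic acid, or a saturated ring such as piperidine.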